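Swapping 2,5-difluorophenyl for 2-methoxyphenyl: a toxicity question

The compounds below may be only part of what the source reports. "The series", "measured", "known", "first", "only" and "open" are said of these compounds alone.

Measured so far in an ADME assay on BHK cells (Mesocricetus auratus) for cytotoxicity, read by MTT assay; on this read-out lower numbers stand for higher toxicity in this test and higher numbers for lower toxicity in this test:
compound 1 `OC[C@@H]1[C@@H](O)[C@H](O)[C@@H](O)CN1CCCCCCOc1cc(F)ccc1F` gives > 500000 nM
compound 2 `OC[C@@H]1[C@@H](O)[C@H](O)[C@@H](O)CN1CCCCCCOc1c(F)c(F)c(F)c(F)c1F` gives > 500000 nM

Neither entry is an exact number, and this matters for anyone reading the table. For compound 1, > 500000 nM is a limit of the assay. Compound 1 therefore has no exact position on the scale, and it shares its place with compound 2 at the limit of > 500000 nM in this assay, at which 2 of the 2 values shown sit, in the data so far.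

The next compound is compound 3 `COc1ccccc1OCCCCCCN1C[C@H](O)[C@@H](O)[C@H](O)[C@H]1CO`, which keeps the core of compound 1 and changes only the group at the end of the chain. It carries 2-methoxyphenyl in place of 2,5-difluorophenyl on an oxygen on a saturated carbon and so differs in its aromatic group.

For the measured compounds named here, no measured step between two compounds is available in this assay to guide a prediction. The expectation rests on the shared limit, (the limit of > 500000 nM in this assay, at which 2 of the 2 values shown sit), which gives no sign of toxicity in either measured compound. The estimated a number no higher from compound 1 to compound 3 (the limit leaves the size open) is expected to stay within the usual scatter, with no clear direction. For compound 3 the estimated value is 500000 nM with an expected range from 250000 nM to 900000 nM and a good chance of another limit.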

Compound 3, half-maximal cytotoxic concentration in the BHK assay: > 500000 nM
Compound 3 was reported as a limit (the forecaster's own chance of this, stated with the estimate: 70%); the middle value lies on the limit itself.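

In the BHK assay compound 3 gives > 500000 nM and this is a limit of the assay. For the compounds shown here, compound 1 also stands at a limit there, so no step between compound 1 and compound 3 can be read. The compounds shown share one position: the limit of > 500000 nM in the BHK assay, at which 3 of the 3 values shown sit.

In a physicochemical assay for solubility, in phosphate buffer, at pH 4 (a lower number here means a less soluble compound, a higher number a more soluble compound), compound 1 gives 296000 nM and compound 3 gives 286000 nM as exact values. In the physicochemical assay the swap of groups gives a 1.0-fold lower number from compound 1 to compound 3 (0.01 log units; within the scatter) and so no difference can be claimed.

What they leave open is the concentration at which any of them would harm these cells, and how they would rank against one another.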